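Formyl for hydroxymethyl on the large ring

The source may hold more compounds than are shown below. What is called first, only, known or untested is meant among the compounds shown, and "the series" means these compounds.

Compound 1, `CC(C)=CC(=O)O[C@@H]1/C=C/[C@@](C)(C/C=C/C(C)(C)O)C/C=C(/CO)CC[C@@H]2O[C@]21C`: in a functional assay on P388 cells (Mus musculus) for cytotoxicity (on this read-out higher numbers stand for an effect only at larger amounts of compound and lower numbers for an effect already at smaller amounts), compound 1 gives 2.25 ug/mL.
Compound 2, `C=C(C)C(O)CC[C@]1(C)/C=C/[C@@H](OC(=O)C=C(C)C)[C@]2(C)O[C@H]2CC/C(CO)=C\C1`: in this assay compound 2 gives only a limit, < 10 ug/mL.

Among the measured compounds shown here, compound 1 stands on the only real number in this set; the other value shown is a limit, not a number. For that reason the step that the limit leaves unreadable from compound 1 to compound 2 cannot be read, as the limit of < 10 ug/mL in this assay, at which 1 of the 2 values shown sits, shows. The two structures differ by a 2-hydroxy-3-methylbut-3-en-1-yl in place of a 3-hydroxy-3-methylbut-1-en-1-yl on a saturated chain carbon bound to a saturated ring carbon, a change at a place far from the one now considered.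

Compound 3, `CC(C)=CC(=O)O[C@@H]1/C=C/[C@@](C)(C/C=C/C(C)(C)O)C/C=C(/C=O)CC[C@@H]2O[C@]21C`, differs from compound 1 by formyl in place of hydroxymethyl on a double-bonded ring carbon. For the measured compounds named here, no measured step touches this ring carbon, and the single measured step on record is itself unreadable, so nothing measured bears on this change. Without a precedent, the account expects a step no larger than the usual scatter, in no sure direction. Compound 3 is therefore estimated at 1.5 ug/mL, within 0.4 ug/mL to 6 ug/mL, which means an expected step of a 1.5-fold lower number from compound 1 to compound 3 (0.18 log units; within the scatter).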

Compound 3, concentration for half-maximal effect: < 10 ug/mL
Compound 3 was reported as a limit (the forecaster's own chance of this, stated with the estimate: 10%); the middle value does not contradict the limit.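

In this assay compound 3 gives < 10 ug/mL, a limit and not a number. The change from compound 1 to compound 3 therefore yields no readable step: the limit of < 10 ug/mL in this assay, at which 2 of the 3 values shown sit.

The compounds shown leave open whether formyl in place of hydroxymethyl on the double-bonded ring carbon shifts this read-out at all, and in which direction.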